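Pyridyl series: cytotoxicity on Vero cells, one number so far

The source may hold more compounds than are shown below. What is called first, only, known or untested is meant among the compounds shown, and "the series" means these compounds.

Among the compounds with values here, compound 1 `Fc1ccc(-c2nn3c(NC4CCCC4)cccc3c2-c2ccncc2)cc1` is the only member of this set with a result in an ADME assay on Vero cells (Chlorocebus sabaeus) for cytotoxicity; a higher number here means that more compound is tolerated, a lower number that less compound is tolerated; compound 1 gives 20000 nM. Compound 2 `Fc1ccc(-c2nn3c(NC4CCCC4)cccc3c2-c2ccco2)cc1` and compound 3 `Fc1ccc(-c2nn3c(NC4CCCC4)cccc3c2-c2ccno2)cc1`, which carry other five-membered aromatic groups on the shared core, have no result reported in this assay: for compound 2 the entry reads "not determined" (no result reported), and for compound 3 the entry reads "not determined" (no result reported). Within the data shown here, compound 1 therefore stands alone on the numbers and no step between measured compounds can be read off.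

Compound 4 `Fc1ccc(-c2nn3c(NC4CCCC4)cccc3c2-c2ccnc(NC3CCCC3)c2)cc1` differs from compound 1 in one place: cyclopentylamino in place of hydrogen on an aromatic carbon. The rest of the molecule, including the cyclopentylamino already present on the core of compound 1, is unchanged.

Among the measured compounds shown here, with no measured pair to lean on, the expectation for this change rests on the single value of compound 1 alone. Compound 4 is expected to stay close to compound 1 in this assay, with a step from compound 1 to compound 4 of a 1.3-fold lower number from compound 1 to compound 4 (0.12 log units; within the scatter), that is no step beyond the usual scatter or at most a slight move toward less compound tolerated. Compound 4 is accordingly estimated at 15000 nM in this assay, with a range from 5000 nM to 40000 nM.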

Compound 4, half-maximal cytotoxic concentration: > 40000 nM
Compound 4: a limit, no number; the forecaster's own chance of this, stated with the estimate: 25%; middle value at least 2.6-fold (0.42 log units) from the limit.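

In this assay compound 4 reads as a limit of the assay and not as a number: the limit of > 40000 nM in this assay, at which 1 of the 4 values shown sits.

Cyclopentylamino in place of hydrogen on an aromatic carbon, next to the ring nitrogen of the six-membered aromatic ring with 1 nitrogen, gives an at least 2.0-fold higher number from compound 1 to compound 4 (0.30 log units; that floor lies within the scatter). Within the data shown here, this is the first step that can be read at all, and it shows that this position takes the added group with no fall in the number, although the floor of the step does not by itself establish a rise beyond the scatter.

From the compounds shown here alone, how far the true value of compound 4 lies past the limit stays open, and steps involving compound 2 and compound 3 cannot be read. Also open, going by these compounds, is whether a smaller group at the same position, such as a plain amine, a methylamino or a methoxy group, would read the same way, or whether the result is particular to cyclopentylamino.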